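This account rests on a few compounds, and the source may have more. Where it says the series, first, only, none or still open, it means among the compounds named here.

In a functional assay on BaF3 cells (Mus musculus) for antiproliferative activity (on this read-out lower numbers stand for an effect already at smaller amounts and higher numbers for an effect only at larger amounts of compound), three compounds have been measured: compound 1 (`CCN1CCN(Cc2ccc(NC(=O)c3ccc(C)c(C#Cc4cccnc4)c3)cc2C(F)(F)F)CC1`) gives 1590 nM, compound 2 (`CCN1CCN(Cc2ccc(NC(=O)c3ccc(C)c(C#Cc4cncnc4)c3)cc2C(F)(F)F)CC1`) gives 2190 nM, and compound 3 (`CCN1CCN(Cc2ccc(NC(=O)c3ccc(C)c(C#Cc4cnc5[nH]ccc5c4)c3)cc2C(F)(F)F)CC1`) gives 1000 nM. The place of compound 3 rests on two steps: there is a 1.6-fold lower number from compound 1 to compound 3 (0.20 log units; within the scatter), and there is a 2.2-fold lower number from compound 2 to compound 3 (0.34 log units; beyond the scatter). It therefore cannot be separated from compound 1, and it stands only modestly apart from compound 2.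

Compound 4 (`CCN1CCN(Cc2ccc(NC(=O)c3ccc(C)c(C#Cc4coc5ccccc45)c3)cc2C(F)(F)F)CC1`) carries 1-benzofuran-3-yl on the triple-bonded carbon, and the change is a group of 9 heavy atoms (8 carbon, 1 oxygen; one five-membered aromatic ring with 1 hetero atom, one six-membered aromatic ring of carbon only) in place of a group of 9 heavy atoms (7 carbon, 2 nitrogen; one five-membered aromatic ring with 1 hetero atom, one six-membered aromatic ring with 1 hetero atom), on a triple-bonded carbon. Among the measured compounds shown here, no measured step makes this exchange, so the evidence is indirect. The three steps at the same carbon are all small, including a 1.4-fold higher number from compound 1 to compound 2 (0.14 log units; within the scatter), and only one of them lies beyond the scatter. A large shift in this assay is therefore not expected. The estimate stays within the span of the measured compounds, and what is expected is a 1.5-fold higher number from compound 3 to compound 4 (0.18 log units; within the scatter), with no step beyond the scatter. Compound 4 is expected at 1500 nM, within an estimated range of 600 nM to 3800 nM.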

Compound 4, half-maximal effective concentration: 6760 nM
Compound 4: the middle estimate sits 4.5-fold (0.65 log units) below what was measured, and the stated range ends below it.
By their numbers in this assay, from the lowest: compounds 3, 1 and 2 (each within the scatter of the next, the first and the last beyond it); then compound 4.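

In this assay, among the compounds shown here, the triple-bonded carbon turns out to be more sensitive to the group it carries than the earlier compounds showed, for there is a 6.8-fold higher number from compound 3 to compound 4 (0.83 log units; beyond the scatter) and also a 4.3-fold higher number from compound 1 to compound 4 (0.63 log units; beyond the scatter) as well as a 3.1-fold higher number from compound 2 to compound 4 (0.49 log units; beyond the scatter) with 1-benzofuran-3-yl in each case. Compound 3 and compound 4 carry groups with the same count of heavy atoms and the same ring sizes, so these counts alone do not set the number here; the groups differ in their atoms and in the hydrogen-bond donor, which only the group of compound 3 has. No measurement at hand explains this rise. The compounds shown leave open whether the ring nitrogen, the donor, the oxygen or the point of attachment matters most. Phenyl or indol-3-yl on the same carbon would help to separate these.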